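The source may hold more compounds than are shown below. What is called first, only, known or untested is meant among the compounds shown, and "the series" means these compounds.

Measured compounds:
compound 1 `O=C(Nc1ccc(Oc2ccnc3[nH]ccc23)cc1)c1nccc(-c2ccc(F)cc2)n1`, "not active" (no number reported) in a functional assay on A549 cells (Homo sapiens) for cytotoxicity, read by MTT assay, with a stated time of 72 h; a higher number here means a weaker inhibitor, a lower number a stronger inhibitor
compound 2 `COc1ccc(-c2cc(C(=O)Nc3ccc(Oc4ccnc5[nH]ccc45)cc3)ncn2)cc1`, 4410 nM
compound 3 `COc1ccc(-c2cc(C(=O)Nc3ccc(Oc4ccnc5[nH]ccc45)c(F)c3)ncn2)cc1`, 4210 nM

Compound 3 has the lowest of the two numbers reported in this assay, but its nearest neighbour is compound 2, and the step of a 1.0-fold lower number from compound 2 to compound 3 (0.02 log units; within the scatter) lies within the scatter, so the two cannot be told apart. Compound 1 carries a different core and is reported only as "not active" (no number reported), without a number.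

Compound 4 `O=C(Nc1ccc(Oc2ccnc3[nH]ccc23)c(F)c1)c1cc(-c2ccc(C(F)(F)F)cc2)ncn1` differs from compound 3 in one place: trifluoromethyl in place of methoxy on an aromatic carbon. Within the data shown here, no measured step touches this group. Among the measured compounds shown here, the only measured step, from compound 2 to compound 3, concerns fluoro in place of hydrogen elsewhere in the molecule and says nothing about what an exchange of methoxy for trifluoromethyl does. Compound 1, which bears a fluoro on the corresponding phenyl ring but on another core, gives no usable number. For the measured compounds named here, with no bearing step, the expectation for compound 4 is a step of about a 1.2-fold higher number from compound 3 to compound 4 (0.07 log units; within the scatter), that is, none beyond the scatter, with a wide range to reflect the missing precedent. Compound 4 is therefore estimated at 5000 nM, between 1500 nM and 20000 nM.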

Compound 4, half-maximal inhibitory concentration: 2220 nM
Compound 4: the middle estimate sits 2.3-fold (0.35 log units) above what was measured, and the stated range covers the measured number.
By their numbers in this assay, from the lowest: compounds 4, 3 and 2 (each within the scatter of the next).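

In this assay, among these compounds, the step of a 1.9-fold lower number from compound 3 to compound 4 (0.28 log units; within the scatter) is the first measured change at this place, on the six-membered aromatic ring of carbon only and para to a large group. Going from 4-methoxyphenyl to 4-(trifluoromethyl)phenyl replaces a group bearing oxygen, which counts as one hydrogen-bond acceptor, with a larger group of carbon and fluorine that counts as none, yet compound 3 and compound 4 cannot be told apart in this cell assay, so neither the oxygen nor the size of the group shows up here as a measurable requirement. No measurement shown explains this outcome.

From the compounds shown here alone, it remains open whether a quite different group at this place, such as an amine, a carboxylic acid or a longer chain like butoxy, would also stay within the scatter or would move the number clearly. Going by these compounds, it is equally open whether trifluoromethyl would read the same without the fluoro that compound 3 and compound 4 share, and whether any of these numbers reflect action on a particular target rather than general cytotoxicity.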